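The compounds below may be only part of what the source reports. "The series", "measured", "known", "first", "only" and "open" are said of these compounds alone.

In an ADME assay on Vero 76 cells (Chlorocebus sabaeus) for cytotoxicity, read by crystal violet staining, with a stated time of 96 h (on this read-out lower numbers stand for higher toxicity in this test and higher numbers for lower toxicity in this test), three thiourea compounds built on a shared core have been measured. Compound 1 `COc1cccc(NC(=S)Nc2cccc(C(F)(F)F)c2)c1` gives 20000 nM, and compound 3 `O=[N+]([O-])c1ccc(NC(=S)Nc2cccc(C(F)(F)F)c2)cc1` gives 10000 nM. Compound 2 `C=C(C)CNC(=S)Nc1cccc(C(F)(F)F)c1` reaches only > 100000 nM, which is a limit of the assay rather than a number. That places compound 2 at the limit of > 100000 nM in this assay, at which 1 of the 3 values shown sits, so its exact position among the measured values is not fixed; it is known only to sit at the least toxic edge of what this assay can report. Among the compounds with values here, no two measured compounds differ in a single place, so no measured step can be drawn from them.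

Compound 4 `CC(=O)NC(=S)Nc1cccc(C(F)(F)F)c1` is the compound still to be measured. It differs from compound 2 by acetyl in place of 2-methylprop-2-en-1-yl on an amide-type nitrogen. Since compound 2 shows only a limit, the step from compound 2 to compound 4 is expected to be small in either direction, within the scatter, with an at least 1.1-fold lower number from compound 2 to compound 4 (0.04 log units; that floor lies within the scatter) as the expected size. Compound 4 is therefore expected to give about 90000 nM, with a plausible range from 30000 nM to 250000 nM, and a fair chance that this assay again reports only a limit.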

Compound 4, half-maximal cytotoxic concentration: > 100000 nM
Compound 4: a limit, no number; the forecaster's own chance of this, stated with the estimate: 55%; middle value at least 1.1-fold (0.04 log units) away from the limit.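

Compound 2 and compound 4 both give only a limit in this assay, not a number, so no step can be read between them: the limit of > 100000 nM in this assay, at which 2 of the 4 values shown sit.

The compounds shown leave open whether acetyl in place of 2-methylprop-2-en-1-yl changes the value at all, and in which direction.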